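This account rests on a few compounds, and the source may have more. Where it says the series, first, only, none or still open, it means among the compounds named here.

Going by the values given here, compound 2 `COc1n[nH]c2ncc(C#Cc3c(F)ccc(NS(=O)(=O)c4cccc(Br)c4)c3F)cc12` holds the lowest of the two numbers so far in an assay on cells for inhibition of mitogen-activated protein kinase kinase kinase 20 (Homo sapiens), read by ADP-Glo, with a stated time of 30 min (on this read-out higher numbers stand for weaker inhibition and lower numbers for stronger inhibition), where compound 2 gives 5 nM; its nearest neighbour is compound 1 `COc1n[nH]c2ncc(C#Cc3c(F)ccc(NS(=O)(=O)c4ccccc4)c3F)cc12`, which in this assay gives 19.2 nM. Among the compounds with values here, the only measured step, a 3.8-fold lower number from compound 1 to compound 2 (0.58 log units; beyond the scatter), is the bromo in place of hydrogen on an aromatic carbon. Compound 3 `COc1n[nH]c2ncc(C#Cc3c(F)ccc(NS(=O)(=O)c4cccc(Cl)c4Cl)c3F)cc12` carries 2,3-dichlorophenyl in place of 3-bromophenyl on a sulfonyl sulfur. Within the data shown here, no measured step covers this exchange; the sole step shows that a halogen on that phenyl is tolerated and modestly helps, so the expected step of a 1.2-fold higher number from compound 2 to compound 3 (0.08 log units; within the scatter) is small, within the scatter. Compound 3 is therefore estimated at 6 nM, in the range 2 nM to 18 nM.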

Compound 3, half-maximal inhibitory concentration: 9.6 nM
Compound 3: the middle estimate sits 1.6-fold (0.20 log units) below what was measured; low and high end bracket the measured number.
By their numbers in this assay, from the lowest: compounds 2, 3 and 1 (each within the scatter of the next, the first and the last beyond it).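

In this assay 2,3-dichlorophenyl on the sulfonyl sulfur cannot be told apart from 3-bromophenyl (a 1.9-fold higher number from compound 2 to compound 3 (0.28 log units; within the scatter)) or from phenyl (a 2.0-fold lower number from compound 1 to compound 3 (0.30 log units; within the scatter)). Going by these compounds alone, this position therefore accepts two chlorines as well as one bromine, while the bromo exchange (a 3.8-fold lower number from compound 1 to compound 2 (0.58 log units; beyond the scatter)) remains the only step beyond the scatter. Nothing available explains these numbers.

Still open, going by these compounds, is how a methoxy, a nitrile or an amine on this phenyl would read. Also open, on these data alone, is whether a cyclopropyl on the sulfonyl sulfur would hold these numbers.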